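Oxidising the Sulfur Substituent of Compound 3

A few compounds are considered here, and "the series" means these few. Any claim that something is new, unique, unknown or untested is made for them only; others in the source may bear on it.

Compound 1 `NC1=C(Cl)C(=O)c2ncccc2C1=O`: in a functional assay on cells (Neutrophil, Homo sapiens) for inhibition, read by WST assay, with a stated time of 20 min (on this read-out higher numbers stand for weaker inhibition and lower numbers for stronger inhibition), compound 1 gives > 200000 nM, which is a limit of the assay and not a number.
Compound 2 `CS(=O)(=O)C1=C(N)C(=O)c2cccnc2C1=O`: in this assay compound 2 gives > 200000 nM, also a limit.
Compound 3 `CNC1=C(SC)C(=O)c2cccnc2C1=O`: in this assay compound 3 gives > 200000 nM, again a limit.

Compound 3 thus stands where every value shown stands, at the limit of > 200000 nM in this assay, at which 3 of the 3 values shown sit. Within the data shown here, the one step between measured compounds, a step that the two limits leave unreadable from compound 1 to compound 2, is left unreadable by those limits, so no measured step shows how large a change at this position can be. Compound 4 `CNC1=C([S+](C)[O-])C(=O)c2cccnc2C1=O` differs from compound 3 in a group of 3 heavy atoms (1 carbon, 1 oxygen, 1 sulfur; no ring) in place of a group of 2 heavy atoms (1 carbon, 1 sulfur; no ring), on a double-bonded ring carbon. Because all three values sit at the limit of > 200000 nM in this assay, at which 3 of the 3 values shown sit, the step of a number no higher from compound 3 to compound 4 (the limit leaves the size open) is expected to stay within that limit. Compound 4 is estimated at 200000 nM, between 50000 nM and 1000000 nM.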

Compound 4, half-maximal inhibitory concentration: > 200000 nM
Compound 4: a limit, no number; the forecaster's own chance of this, stated with the estimate: 80%; the middle value sits exactly at the limit.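

Among these compounds, no step from compound 3 to compound 4 can be read, as both values are limits and not numbers: the limit of > 200000 nM in this assay, at which 4 of the 4 values shown sit.
The compounds shown leave open which change to the shared core, if any, would give a real number in this assay.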